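Swapping methylamino for hydroxy on a carbonyl carbon

The compounds below may be only part of what the source reports. "The series", "measured", "known", "first", "only" and "open" are said of these compounds alone.

For the measured compounds named here, in a functional assay on A549 cells (Homo sapiens) for inhibition, read by sulforhodamine B assay, with a stated time of 72 h (a lower number here means a stronger inhibitor of growth, a higher number a weaker inhibitor of growth), compound 2 `CNC(=O)CCc1ccncc1-c1ccc2ccccc2c1` gives 10400 nM, the only true number available so far. Compound 1 `O=C(O)/C=C/c1ccncc1-c1ccc2ccccc2c1` gives > 10000 nM, which is a limit of the assay and not a number.

The next compound, compound 3 `O=C(O)CCc1ccncc1-c1ccc2ccccc2c1`, differs from compound 2 at one place: hydroxy in place of methylamino on a carbonyl carbon. Hydroxy stands in place of methylamino on a carbonyl carbon, so 2-(methylcarbamoyl)ethyl becomes 2-carboxyethyl.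

Going by the values given here, the only measured step is a step that the limit leaves unreadable from compound 1 to compound 2, so it offers no size to carry over to this change. It still gives a weak hint about direction. A small move towards weaker growth inhibition, meaning a higher number, is expected because compound 1 also carries a carboxy group and stands at the limit of > 10000 nM in this assay, at which 1 of the 2 values shown sits. That rests on one compound, and compound 1 has a 2-carboxyethenyl group, not a 2-carboxyethyl group. The expected step is a 1.3-fold higher number from compound 2 to compound 3 (0.13 log units; within the scatter), which may prove no larger than the scatter, and compound 3 may also end up reported only as a limit. The estimated value for compound 3 is 14000 nM, with an expected range of 6000 nM to 30000 nM.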

Compound 3, concentration for 50% growth inhibition: > 10000 nM
Compound 3 was reported as a limit; the forecaster's own chance of this, stated with the estimate: 55%; the middle value lies beyond the limit too.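

Compound 3 is reported only as a limit of the assay, not as a number, and the steps to it from compound 1 and from compound 2 cannot be read. The compounds shown leave open how strongly compound 1 and compound 3 actually inhibit growth, and whether hydroxy in place of methylamino on a carbonyl carbon changes growth inhibition at all.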